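The source may report more compounds than this note shows. Statements on the series, on what has been measured and on what is new or still open speak of the compounds shown alone.

Three compounds that share one core and differ on an amide-type nitrogen have been measured in a physicochemical assay for lipophilicity, at pH 7.4; a higher number here means a more lipophilic compound, a lower number a more polar compound: compound 1 (`CNC(=O)c1cc(C(=O)N[C@H]2[C@@H]3COC[C@@H]32)cc2c1O[C@H](CF)[C@H]2c1ccccc1`) gives 3.6, compound 2 (`CNC(=O)c1cc(C(N)=O)cc2c1O[C@H](CF)[C@H]2c1ccccc1`) gives 2.9, and compound 3 (`CNC(=O)c1cc(C(=O)NCCC[C@H]2OC[C@H](N)CO2)cc2c1O[C@H](CF)[C@H]2c1ccccc1`) gives 2.9. Compound 3 thus sits level with compound 2 and apart from compound 1. The measured steps show this as no change at the digits printed from compound 2 to compound 3 (within the scatter) and a number 0.70 log units lower from compound 1 to compound 3 (beyond the scatter).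

Compound 4 (`CNC(=O)c1cc(C(=O)NC2CC2)cc2c1O[C@H](CF)[C@H]2c1ccccc1`) differs from compound 3 on that same nitrogen, and the change is a group of 3 heavy atoms (3 carbon; one three-membered non-aromatic ring of carbon only) in place of a group of 10 heavy atoms (7 carbon, 1 nitrogen, 2 oxygen; one six-membered non-aromatic ring with 2 hetero atoms), on an amide-type nitrogen. Within the data shown here, the entering group is cyclopropyl, which no measured compound carries, so the evidence is indirect. The closest guide is the step of a number 0.70 log units lower from compound 1 to compound 2 (beyond the scatter), which spans a hydrogen atom and the group of compound 1, a group that also holds a three-membered ring of carbon only. Cyclopropyl is smaller than that group but is more than a hydrogen atom, so compound 4 is expected to fall within that span, nearer to compound 1 with 3.6 than to compound 3 with 2.9. A modest rise is therefore expected in this assay, with an estimated a number 0.50 log units higher from compound 3 to compound 4 (beyond the scatter). Compound 4 is estimated at 3.4, with an expected range from 3 to 3.8.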

Compound 4, distribution coefficient: 3.9
Compound 4: the middle estimate sits 0.50 log units below what was measured; measured number outside the range, above it.
By their numbers in this assay, from the lowest: compounds 2 and 3 (each within the scatter of the next); then compounds 1 and 4 (each within the scatter of the next).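

In this assay, among these compounds, cyclopropyl in place of hydrogen on the amide-type nitrogen gives a number 1.00 log units higher from compound 2 to compound 4 (beyond the scatter), the first direct reading of this group at this position, and the group of 10 heavy atoms in compound 3 gives way to cyclopropyl with a number 1.00 log units higher from compound 3 to compound 4 (beyond the scatter). Compound 4 is not told apart from compound 1, a number 0.30 log units higher from compound 1 to compound 4 (within the scatter), so across these four compounds the number does not follow the heavy-atom count of the group on this nitrogen: compounds 1 and 4 stand together above compound 2, while compound 3, with the largest group, goes against any rise with size by staying level with compound 2. Nothing available accounts for this ordering.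

The compounds shown leave open where a methyl group or a cyclobutyl group on the same nitrogen would fall relative to cyclopropyl. They also leave open whether the group of compound 3 would stay level with compound 2 without its amine, or with a shorter chain leading to its six-membered ring.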